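The source may hold more compounds than are shown below. What is called first, only, known or untested is meant among the compounds shown, and "the series" means these compounds.

Compound 1 `Nc1nc(N)c(-c2ccc(CNc3ccc([N+](=O)[O-])cc3)cc2)c(COCc2ccccc2)n1` and compound 2 `CCc1nc(N)nc(N)c1-c1ccc(CNc2ccc([N+](=O)[O-])cc2)cc1` share one core; in a functional assay on CHOK cells for antagonist activity at growth hormone secretagogue receptor type 1 (Homo sapiens), read by calcium flux (on this read-out lower numbers stand for stronger inhibition and higher numbers for weaker inhibition), compound 1 gives 16 nM, while compound 2 gives 190 nM, the higher of the two numbers shown, with a 12-fold higher number from compound 1 to compound 2 (1.07 log units; beyond the scatter) separating them. Compound 3 `CCc1nc(N)nc(N)c1-c1ccc(CNc2ccc(S(C)(=O)=O)cc2)cc1` carries methylsulfonyl in place of nitro on an aromatic carbon. Going by the values given here, the single measured step concerns a different position and tells nothing about this exchange, so no measured step bears on it. He therefore expects no change beyond the scatter in this assay for compound 3, estimating a 1.3-fold higher number from compound 2 to compound 3 (0.12 log units; within the scatter). His estimate for compound 3 is 250 nM, with a range from 80 nM to 800 nM.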

Compound 3, half-maximal inhibitory concentration: 120 nM
The estimate for compound 3 lay 2.1-fold (0.32 log units) above the measured number; low and high end bracket the measured number.
By their numbers in this assay, from the lowest: compound 1; then compounds 3 and 2 (each within the scatter of the next).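

In this assay the exchange of nitro for methylsulfonyl, on an aromatic carbon para to a large group, gives a 1.6-fold lower number from compound 2 to compound 3 (0.20 log units; within the scatter) and so stays within the scatter. This position therefore takes methylsulfonyl, with its extra heavy atom and second double bond outside the ring, in place of nitro without a measurable change in this read-out. Nothing shown accounts for this result.

As far as these compounds go, it remains open whether an amine or a carboxylic acid at this position would also stay within the scatter. From the compounds shown here alone, it is equally open whether the same exchange would hold with the benzyloxy-bearing chain of compound 1 in place of the ethyl group.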